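From formyl to an ester side chain

The compounds below may be only part of what the source reports. "The series", "measured", "known", "first", "only" and "open" are said of these compounds alone.

Measured compounds:
Compound 1 `C=C[C@@](C)(/C=C/c1ccc(O)c(/C=C/C(=O)OCC)c1)CCC=C(C)C` gives > 36600 nM as a limit
Compound 2 `COc1ccc(/C=C/[C@@](C)(/C=C/c2ccc(O)c(C=O)c2)CCC=C(C)C)cc1` gives 4550 nM as a number

In a functional assay on SEM cells (Homo sapiens) for cytotoxicity, with a stated time of 72 h (a lower number here means that less compound is needed, a higher number that more compound is needed for the effect), compound 2 gives 4550 nM as the only actual number shown. The reading of compound 1 is a limit of the assay, and compound 1, which also carries an ethyl ester, sits at the limit of > 36600 nM in this assay, at which 1 of the 2 values shown sits, here. Compound 3 `CCOC(=O)/C(C)=C/c1cc(/C=C/[C@](C)(/C=C/c2ccc(OC)cc2)CCC=C(C)C)ccc1O` has 2-(ethoxycarbonyl)prop-1-en-1-yl in place of formyl on an aromatic carbon. Within the data shown here, no measured step covers this change. The expected step is a 4.0-fold higher number from compound 2 to compound 3 (0.60 log units; beyond the scatter) towards more compound needed, beyond the scatter. For compound 3 the estimated value is 18000 nM with an expected range of 6000 nM to 50000 nM for now.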

Compound 3, half-maximal effective concentration: > 36600 nM
Compound 3: no number, only a limit; the forecaster's own chance of this, stated with the estimate: 40%; at least 2.0-fold (0.30 log units) between middle value and limit.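

In this assay, putting 2-(ethoxycarbonyl)prop-1-en-1-yl in place of formyl on this aromatic carbon, ortho to a hydroxy group, gives an at least 8.0-fold higher number from compound 2 to compound 3 (0.90 log units; beyond the scatter). Among these compounds, this is the first comparison at this position that changes one place only, and it ties the loss of a measurable number to this change alone. The reading of compound 3 is a limit and not a number: the limit of > 36600 nM in this assay, at which 2 of the 3 values shown sit.

The compounds shown leave open whether a carboxylic acid or a hydroxymethyl group at this position would give a number near that of compound 2.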